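Pyrrolidine for Piperidine on a Thienopyrimidine Ether Core

The source may report more compounds than this note shows. Statements on the series, on what has been measured and on what is new or still open speak of the compounds shown alone.

Three measured compounds frame the question. In a functional assay on A549 cells (Homo sapiens) for inhibition, read by MTT assay, with a stated time of 72 h, tested at 20 uM (a lower number here means less inhibition, a higher number more inhibition at the concentration tested (going by the name of the read-out)), compound 1 `CNC(=O)c1cc(Oc2ccc(Nc3nccc(N4CCCC4)n3)cc2)ccn1` gives 59.6%, compound 2 `CNC(=O)c1cc(Oc2ccc(Nc3nccc(N4CCCCC4)n3)cc2)ccn1` gives 63.4%, and compound 3 `c1cc(N2CCCCC2)nc(Nc2ccc(Oc3ncnc4ccsc34)cc2)n1` gives 59.9%. Compounds 1 and 2 share a core and differ in one place: pyrrolidin-1-yl in place of piperidin-1-yl on an aromatic carbon. That change produced a number 3.8 percentage points lower from compound 2 to compound 1 (within the scatter), so the two amide-bearing compounds are indistinguishable within the usual scatter. Compounds 2 and 3 differ in their cores: a group of 9 heavy atoms (6 carbon, 2 nitrogen, 1 sulfur; one five-membered aromatic ring with 1 hetero atom, one six-membered aromatic ring with 2 hetero atoms) in place of a group of 10 heavy atoms (7 carbon, 2 nitrogen, 1 oxygen; one six-membered aromatic ring with 1 hetero atom), on an oxygen on an aromatic ring. This exchange gave a number 3.5 percentage points lower from compound 2 to compound 3 (within the scatter), again not separable from measurement noise.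

Compound 4 `c1cc(N2CCCC2)nc(Nc2ccc(Oc3ncnc4ccsc34)cc2)n1` has not yet been measured in this assay. It stands to compound 3 as compound 1 stands to compound 2, with the same change made on the same place: pyrrolidin-1-yl in place of piperidin-1-yl on an aromatic carbon. Because the earlier instance of this change produced a number 3.8 percentage points lower from compound 2 to compound 1 (within the scatter), the step expected here is a number 2.9 percentage points lower from compound 3 to compound 4 (within the scatter), resting on a single precedent and on the observation that neither change so far moved the read-out beyond the scatter. Compound 4 is therefore estimated at 57%, with a plausible range from 46% to 68%.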

Compound 4, a percentage reported as inhibition, at one concentration (the size of the read-out at that concentration, not a potency): 23.2%
Beside the measured number, compound 4's estimate is 33.8 percentage points above it, and the stated range ends above it.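

In this assay, pyrrolidin-1-yl in place of piperidin-1-yl gave a number 36.7 percentage points lower from compound 3 to compound 4 (beyond the scatter), so the change did not carry over from one core to the other with the same size of step: the same change on two cores in this assay, a number 3.8 percentage points lower (within the scatter) from compound 2 to compound 1 and a number 36.7 percentage points lower (beyond the scatter) from compound 3 to compound 4, 32.9 percentage points apart, beyond the scatter of two such steps

Within these four compounds, then, the effect of this exchange depends on the core that carries it, and a step measured on one core is a poor guide to the step on the other. The data do not show which part of the core is responsible, since the two cores differ in the whole group on the oxygen, and two cores establish no rule for the series; the read-out also comes from a single concentration and is not a potency.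

The compounds shown leave open how the exchange behaves on any third core, and so which of the two steps is the more typical. They also leave open what other amines on the same aromatic carbon, such as morpholin-4-yl or dimethylamino, would do on each of the two cores.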